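A Spirocyclic Amine Replaces a Bicyclic Alcohol

This account rests on a few compounds, and the source may have more. Where it says the series, first, only, none or still open, it means among the compounds named here.

Going by the values given here, compound 1 `Cn1nc(-c2ccc(OCC34CCC(O)(CC3)CC4)c(F)c2)c2cnc(N)nc21` is the one compound here with a number: in an assay on tissue (PBMC cells) for antagonist activity at Toll-like receptor 9 (Homo sapiens) (on this read-out lower numbers stand for stronger inhibition and higher numbers for weaker inhibition), compound 1 gives 5300 nM. Compound 2 `Cc1cc(-c2ccnc3[nH]ncc23)cnc1OCC12CCC(O)(CC1)CC2` reaches only a limit of the assay, giving > 5000 nM in this assay. Beside the single number stands only (the limit of > 5000 nM in this assay, at which 1 of the 2 values shown sits). Compound 3 `Cn1nc(-c2ccc(OCC3CC4(CNC4)C3)c(F)c2)c2cnc(N)nc21` differs from compound 1 by a group of 7 heavy atoms (6 carbon, 1 nitrogen; one four-membered non-aromatic ring of carbon only, one four-membered non-aromatic ring with 1 hetero atom) in place of a group of 9 heavy atoms (8 carbon, 1 oxygen; 2 six-membered non-aromatic rings of carbon only), on a saturated chain carbon bound to an oxygen on an aromatic ring. Among the compounds with values here, no measured pair shows a change of this kind, so the step of a 1.8-fold lower number from compound 1 to compound 3 (0.25 log units; within the scatter) is expected to be modest, not far beyond the scatter, with no firm direction. Compound 3 is therefore expected to give about 3000 nM in this assay, somewhere from 800 nM to 12000 nM.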

Compound 3, half-maximal inhibitory concentration: 6500 nM
Estimate against measurement, compound 3: 2.2-fold (0.34 log units) below; the measured number falls inside the stated range.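

In this assay, the spirocyclic amine in place of the bicyclic alcohol gives a 1.2-fold higher number from compound 1 to compound 3 (0.09 log units; within the scatter). On a saturated chain carbon bound to an oxygen on an aromatic ring, then, the alcohol can give way to a ring amine with no readable change in inhibition. Compound 2 gives only a limit of the assay, and the other readings lie close to it: the limit of > 5000 nM in this assay, at which 1 of the 3 values shown sits.

Going by these compounds, whether any group at this place can give much stronger inhibition stays open. An open-chain amine or a carboxylic acid on a longer chain could show whether this position matters at all.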